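The compounds below may be only part of what the source reports. "The series", "measured", "known", "first", "only" and "open" are said of these compounds alone.

Measured in an assay on isolated protein for displacement of a labelled ligand from Apoptosis regulator Bcl-2 (Homo sapiens), read by fluorescence polarization; on this read-out higher numbers stand for weaker inhibition and lower numbers for stronger inhibition:

compound 1 `CN(C)CC[C@H](CSc1ccccc1)Nc1ccc(S(=O)(=O)NC(=O)c2ccc(N3CCC(=Cc4ccccc4C#N)CC3)cc2)cc1[N+](=O)[O-]`: 13 nM
compound 2 `CN(C)CC[C@H](CSc1ccccc1)Nc1ccc(S(=O)(=O)NC(=O)c2ccc(N3CCC4(CC3)CC(c3ccccc3)=NO4)cc2)cc1[N+](=O)[O-]`: 35.2 nM
compound 3 `CN(C)CC[C@H](CSc1ccccc1)Nc1ccc(S(=O)(=O)NC(=O)c2ccc(N3CCN(C(=O)Nc4ccccc4)CC3)cc2)cc1[N+](=O)[O-]`: 300 nM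

Compound 3 stands highest of the three numbers in this assay; compound 2 sits well below it, and compound 1 lower still, both gaps lying beyond the usual scatter. Compound 3 is thus the weakest of the set as measured.

Compound 4 `CN(C)CC[C@H](CSc1ccccc1)Nc1ccc(S(=O)(=O)NC(=O)c2ccc(N3CCN(Cc4ccccc4)CC3)cc2)cc1[N+](=O)[O-]` has not been measured in this assay. It differs from compound 3 in one place: benzyl in place of phenylcarbamoyl on an amine nitrogen in a ring. The ring amine nitrogen thereby carries a benzyl group instead of the phenylcarbamoyl group, so the carbonyl and the amide hydrogen of compound 3 are gone and a plain phenyl-bearing one-carbon link remains.

Going by the values given here, no measured pair shows this exact exchange, so the expected step rests on the spread among compounds 1 to 3. The step from compound 3 to compound 4 in this assay is expected to be a 3.8-fold lower number from compound 3 to compound 4 (0.57 log units; beyond the scatter), toward lower numbers, and likely beyond the scatter, with considerable uncertainty. Compound 4 is therefore expected to give 80 nM in this assay, within a range of 20 nM to 320 nM.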

Compound 4, inhibition constant: 39.8 nM
Compound 4: the middle estimate sits 2.0-fold (0.30 log units) above what was measured; the measured number falls inside the stated range.
By their numbers in this assay, from the lowest: compound 1; then compounds 2 and 4 (each within the scatter of the next); then compound 3.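

Going by these compounds alone, on the amine nitrogen in the six-membered ring with two nitrogens, benzyl in place of phenylcarbamoyl gives a 7.5-fold lower number from compound 3 to compound 4 (0.88 log units; beyond the scatter) in this assay, the first one-place comparison. With a phenyl ring present on both sides of the exchange, the number at this position depends on what links that ring to the ring nitrogen, and the carbonyl and the amide hydrogen are not required for binding at this level. No supporting measurement accounts for the size of this step.

A benzoyl group, which would keep the carbonyl without the amide hydrogen, could show which of the two lost features matters. Going by these compounds, whether a phenethyl chain, with a longer link, or a phenyl ring set directly on the ring nitrogen would lower the number further remains open.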